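Replacing the amine substituent of compound 2

A few compounds are considered here, and "the series" means these few. Any claim that something is new, unique, unknown or untested is made for them only; others in the source may bear on it.

Values in an ADME assay on NCM460 cells (Homo sapiens) for cytotoxicity, read by CCK-8 assay, with a stated time of 48 h; on this read-out lower numbers stand for stronger inhibition and higher numbers for weaker inhibition:
- compound 1 `COc1ccc(/C=C\c2cc(OC)c(OC)c(OC)c2)cc1OCc1ccc(CN2CCCC[C@H]2C(=O)O)cc1`: > 50000 nM, a limit
- compound 2 `COc1ccc(/C=C\c2cc(OC)c(OC)c(OC)c2)cc1OCc1ccc(CN[C@H](C(=O)O)[C@H](C)O)cc1`: > 50000 nM, a limit

Compound 2 has no number, only the limit > 50000 nM. The two measured compounds both stand at the limit of > 50000 nM in this assay, at which 2 of the 2 values shown sit. Among the compounds with values here, the one measured step is a step that the two limits leave unreadable from compound 1 to compound 2, so it offers no size to carry forward.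

Compound 3 `COc1ccc(/C=C\c2cc(OC)c(OC)c(OC)c2)cc1OCc1ccc(CNCCO)cc1` has 2-hydroxyethyl in place of 1-carboxy-2-hydroxypropyl on an amine nitrogen. Compounds 1 and 2 both carry a carboxy group and compound 3 has none, so the measured pair gives no direct guide to this change.

The expected change in this assay is an at least 1.6-fold lower number from compound 2 to compound 3 (0.22 log units; that floor lies within the scatter), towards stronger inhibition, though only tentatively, and the same limit may well return. For compound 3 the estimate is 30000 nM, with an expected range from 4000 nM to 50000 nM.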

Compound 3, half-maximal inhibitory concentration: 39000 nM
The estimate for compound 3 lay 1.3-fold (0.11 log units) below the measured number; the range from low to high includes it.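

In this assay, within the data shown here, compound 3, with 2-hydroxyethyl on the amine nitrogen and no carboxy group, gives the first actual number at this position, 39000 nM. That number turns the change into a step with a floor, an at least 1.2-fold lower number from compound 2 to compound 3 (0.10 log units; that floor lies within the scatter), and replacing 2-carboxypiperidin-1-yl with (2-hydroxyethyl)amino reads as an at least 1.2-fold lower number from compound 1 to compound 3 (0.10 log units; that floor lies within the scatter). Both steps remain floors, the step between the two carboxy compounds cannot be read, and those two compounds give only a limit: the limit of > 50000 nM in this assay, at which 2 of the 3 values shown sit.

Compound 3 loses the carboxy group and the rest of the 1-carboxy-2-hydroxypropyl group together, and the compounds shown do not separate the two. From the compounds shown here alone, how a longer chain such as 3-hydroxypropyl, or a morpholine on the same saturated chain carbon, would read in this assay remains open.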